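The compounds below may be only part of what the source reports. "The series", "measured", "known", "first", "only" and "open" are said of these compounds alone.

Among the measured compounds shown here, in a functional assay on HepG2 cells (Homo sapiens) for antiproliferative activity, read by MTT assay, with a stated time of 72 h (a higher number here means a weaker inhibitor, a lower number a stronger inhibitor), compound 1 `CC(=O)NNC(=O)c1csc2ncc(-c3ccc(C)cc3)n12` gives 63600 nM, the higher of the two numbers measured so far, and compound 2 `CCC(=O)NNC(=O)c1csc2ncc(-c3ccc(C)cc3)n12` gives 7340 nM. That gap is an 8.7-fold lower number from compound 1 to compound 2 (0.94 log units; beyond the scatter), and it arises on the saturated chain bound to a carbonyl carbon, not on the aromatic ring. Compound 3 `COc1ccc(-c2cnc3scc(C(=O)NNC(C)=O)n23)cc1` keeps the chain of compound 1 and has methoxy in place of methyl on an aromatic carbon. For the measured compounds named here, no measured step touches this place, so no step beyond the scatter is expected in either direction. The expected step is a 1.2-fold lower number from compound 1 to compound 3 (0.06 log units; within the scatter). For compound 3 the estimate is 55000 nM, with a range from 18000 nM to 160000 nM.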

Compound 3, half-maximal inhibitory concentration: 11800 nM
Estimate against measurement, compound 3: 4.7-fold (0.67 log units) above, outside the stated range (below it).
By their numbers in this assay, from the lowest: compounds 2 and 3 (each within the scatter of the next); then compound 1.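

On this aromatic carbon, para to a large group, methoxy in place of methyl gives a 5.4-fold lower number from compound 1 to compound 3 (0.73 log units; beyond the scatter) in this assay and so shows that the number responds to this place as well as to the saturated chain. Among the compounds shown here, the earlier pair could not show this, since its only step lay on that chain. No evidence at hand explains the step.

Going by these compounds, whether a hydroxy group, an amine or a chlorine at this carbon would lower the number further remains open. So does whether methoxy would give a similar step on the longer chain of compound 2.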